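The source may hold more compounds than are shown below. What is called first, only, known or untested is meant among the compounds shown, and "the series" means these compounds.

Measured compounds in an assay on LX2 cells for inhibition of COL1A1 promoter (Homo sapiens), read by a luciferase reporter, with a stated time of 24 h, tested at 20 uM; a lower number here means a weaker effect, a higher number a stronger effect of the compound at the concentration tested:
compound 1 `Cc1cc(OCCCCCCC[N+]2(C)CCCC2)cc(-n2cc(C(=O)Nc3cc(F)cc(F)c3)c(=O)c3ccc(N(C)C)nc32)c1` — 4.32%
compound 2 `Cc1cc(OCCCCCCC[N+]2(C)CCCCC2)cc(-n2cc(C(=O)Nc3cc(F)cc(F)c3)c(=O)c3ccc(N(C)C)nc32)c1` — 46.8%
compound 3 `CC[N+]1(CCCCCCCOc2cc(C)cc(-n3cc(C(=O)Nc4cc(F)cc(F)c4)c(=O)c4ccc(N(C)C)nc43)c2)CCCC1` — 35.1%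

Compound 3 stands second highest of the three numbers. Its nearest neighbour is compound 2, with a number 11.7 percentage points lower from compound 2 to compound 3 (beyond the scatter); its furthest is compound 1, with a number 30.8 percentage points higher from compound 1 to compound 3 (beyond the scatter).

Compound 4 `Cc1cc(OCCCCCCC[N+](C)(C)C2CCCCC2)cc(-n2cc(C(=O)Nc3cc(F)cc(F)c3)c(=O)c3ccc(N(C)C)nc32)c1` is not yet measured. Its change from compound 3 is a group of 9 heavy atoms (8 carbon, 1 nitrogen; one six-membered non-aromatic ring of carbon only) in place of a group of 7 heavy atoms (6 carbon, 1 nitrogen; one five-membered non-aromatic ring with 1 hetero atom), on a saturated chain carbon, seven bonds along the chain from an oxygen on an aromatic ring. The entering group carries a six-membered non-aromatic ring of carbon only on the charged nitrogen, where compound 3 carries a five-membered ring with one hetero atom.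

Among the compounds with values here, two measured steps bear on the question of how the group on that chain carbon matters. Enlarging the ring by one atom gave a number 42.5 percentage points higher from compound 1 to compound 2 (beyond the scatter); lengthening methyl to ethyl gave a number 30.8 percentage points higher from compound 1 to compound 3 (beyond the scatter). Both point the same way: the larger group on the charged nitrogen gives the higher number, and no listed compound goes against this. Moving from the six-membered to the five-membered ring gave a number 11.7 percentage points lower from compound 2 to compound 3 (beyond the scatter), so the ring size itself counts. Compound 4 carries the largest group of the four, so a step upward in this assay is expected, though the scatter leaves the size uncertain; the expected step is a number 9.9 percentage points higher from compound 3 to compound 4 (within the scatter).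

Compound 4 is estimated at 45%, with a range from 25% to 65%.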

Compound 4, a percentage reported as inhibition, at one concentration (the size of the read-out at that concentration, not a potency): 52.5%
Compound 4: the middle estimate sits 7.5 percentage points below what was measured; measured number inside the range.
By their numbers in this assay, from the lowest: compound 1; then compound 3; then compounds 2 and 4 (each within the scatter of the next).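

In this assay, the six-membered ring of carbon only, in place of the five-membered ring with 1 hetero atom, gave a number 17.4 percentage points higher from compound 3 to compound 4 (beyond the scatter), so at this saturated chain carbon the charged nitrogen need not sit inside a ring for the read-out to hold, while a number 5.7 percentage points higher from compound 2 to compound 4 (within the scatter) means that the ring of carbon only with 9 heavy atoms cannot be told apart from the six-membered ring with 1 hetero atom and 7 heavy atoms. The same group gave a number 48.2 percentage points higher from compound 1 to compound 4 (beyond the scatter), which leaves compound 1 as the weakest of the four, and compound 2 goes against any simple trend with heavy-atom count, since the two extra heavy atoms of compound 4 bring no change beyond the scatter. Nothing on hand offers an explanation for these differences.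

On these data alone, what a neutral tertiary amine, a morpholine ring or a benzyl group on the nitrogen would give at this place remains open, so the need for the net charge of +1 is untested in these compounds. Also open, as far as these compounds go, is whether a ring larger than six-membered, such as an azepane, or a cyclopentyl group on the nitrogen would keep the read-out.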